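Methoxy in place of methyl on an aromatic carbon

A few compounds are considered here, and "the series" means these few. Any claim that something is new, unique, unknown or untested is made for them only; others in the source may bear on it.

Of the compounds shown here, three sharing one core have been measured in a functional assay on CCRF-CEM cells (Homo sapiens) for cytotoxicity; on this read-out lower numbers stand for stronger inhibition and higher numbers for weaker inhibition. Compound 1 `Cc1cccc(C)c1NC(=O)/C=C/C(=O)N1C/C(=C\c2ccccc2)C(=O)/C(=C/c2ccccc2)C1` gives 7400 nM, compound 2 `CC(=O)c1ccc(NC(=O)/C=C/C(=O)N2C/C(=C\c3ccccc3)C(=O)/C(=C/c3ccccc3)C2)cc1` gives 1700 nM, and compound 3 `Cc1ccc(NC(=O)/C=C/C(=O)N2C/C(=C\c3ccccc3)C(=O)/C(=C/c3ccccc3)C2)cc1` gives 1100 nM. Compound 3 thus carries the lowest of the three numbers, but it cannot be separated from compound 2, since a 1.5-fold lower number from compound 2 to compound 3 (0.19 log units; within the scatter) stays within the scatter. Only compound 1 stands clearly apart, with a 6.7-fold lower number from compound 1 to compound 3 (0.83 log units; beyond the scatter).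

Compound 4 `COc1ccc(NC(=O)/C=C/C(=O)N2C/C(=C\c3ccccc3)C(=O)/C(=C/c3ccccc3)C2)cc1` differs from compound 3 in one place: methoxy in place of methyl on an aromatic carbon. This puts methoxy in place of methyl on an aromatic carbon, para to a large group. The closest evidence is the exchange of acetyl and methyl in that same place, a 1.5-fold lower number from compound 2 to compound 3 (0.19 log units; within the scatter), which produced no step beyond the scatter. The larger steps, a 4.4-fold lower number from compound 1 to compound 2 (0.64 log units; beyond the scatter) and a 6.7-fold lower number from compound 1 to compound 3 (0.83 log units; beyond the scatter), were modest, and both replaced 2,6-dimethylphenyl, a change that compound 4 does not make. Going by the values given here, no methoxy compound has yet been measured, so this rests on two neighbours only.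

In this assay, the expected change is therefore none beyond the scatter, with an estimated 1.2-fold higher number from compound 3 to compound 4 (0.07 log units; within the scatter). Compound 4 is estimated at 1300 nM, with an expected range from 600 nM to 2800 nM.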

Compound 4, half-maximal inhibitory concentration: 510 nM
The estimate for compound 4 lay 2.5-fold (0.41 log units) above the measured number; the measured number lies below the stated range.
By their numbers in this assay, from the lowest: compound 4; then compounds 3 and 2 (each within the scatter of the next); then compound 1.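

At the aromatic carbon para to a large group, the change from methyl to methoxy in this assay gives a 2.2-fold lower number from compound 3 to compound 4 (0.33 log units; beyond the scatter) and so moves the read-out, whereas the earlier exchange of acetyl and methyl there stayed within the scatter. Methoxy in place of acetyl gives a 3.3-fold lower number from compound 2 to compound 4 (0.52 log units; beyond the scatter) and widens that contrast, leaving compound 4 with the lowest number of the four, since its steps to all the others lie beyond the scatter. Against the 2,6-dimethylphenyl amide, the 4-methoxyphenyl group gives a 15-fold lower number from compound 1 to compound 4 (1.16 log units; beyond the scatter) as the only large step in this set, and no measurement here explains any of these differences.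

The compounds shown leave open whether the oxygen of methoxy is what matters at this place, and an ethoxy, a hydroxyl or an amine on the same aromatic carbon would help to test that. They also leave open whether methoxy would give a similar step with other substitution on the aryl ring, or on a core with different benzylidene groups.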